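The source may report more compounds than this note shows. Statements on the series, on what has been measured and on what is new or still open speak of the compounds shown alone.

In an ADME assay on MDCK cells (Canis lupus familiaris) for cytotoxicity, read by MTT assay, with a stated time of 2 days (a higher number here means that more compound is tolerated, a lower number that less compound is tolerated), compound 2 `[N-]=[N+]=NCCCCc1ccc(-c2ccc(-c3ccc(-c4cccs4)s3)s2)s1` has no single number, and its entry reads "not determined" (no result reported). Compound 1 `[N-]=[N+]=NCCCCc1ccc(-c2ccc(-c3ccc(-c4ccc(CCCCN=[N+]=[N-])s4)s3)s2)s1` gives the same entry, "not determined" (no result reported). Compound 3 `[N-]=[N+]=NCCCCc1ccc(-c2ccc(-c3cccs3)s2)s1` gives > 200000 nM, which is a limit of the assay and not a number. Compound 4 `NCCCc1ccc(-c2ccc(-c3ccc(-c4cccs4)s3)s2)s1` departs from compound 2 in one place: amino in place of azidomethyl on a saturated chain carbon, three bonds along the chain from an aromatic carbon. Within the data shown here, no measured step guides this change, and compound 2 offers no number to start from. A moderate step towards less compound tolerated in this assay is nevertheless expected, though its size is uncertain. For compound 4 the estimated value is 50000 nM, with an expected range of 10000 nM to 200000 nM.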

Compound 4, half-maximal cytotoxic concentration: > 200000 nM
Compound 4 gave a limit, no number; the forecaster's own chance of this, stated with the estimate: 30%; middle value at least 4.0-fold (0.60 log units) from the limit.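

No new step can be read between compound 2 and compound 4: neither entry is a single number. The compounds shown leave open whether amino in place of azidomethyl changes the outcome in this assay, because the readings stop at one point: the limit of > 200000 nM in this assay, at which 2 of the 4 values shown sit.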